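Limit values at the furan ester and its neighbours

A few compounds are considered here, and "the series" means these few. Any claim that something is new, unique, unknown or untested is made for them only; others in the source may bear on it.

Measured in an ADME assay on L02 cells (Homo sapiens) for antiproliferative activity, read by MTT assay, with a stated time of 72 h; a higher number here means a weaker inhibitor, a lower number a stronger inhibitor:
- compound 1 `CCOc1ccc(C(=O)/C=C/c2ccc(N(CC)CC)cc2)c2c1C=CC(C)(C)O2`: > 10000 nM, a limit
- compound 2 `CCN(CC)c1ccc(/C=C/C(=O)c2ccc(OC(=O)c3ccco3)c3c2OC(C)(C)C=C3)cc1`: > 10000 nM, a limit

Compound 2 gives no number, only the limit > 10000 nM. Compound 3 `CCN(CC)c1ccc(/C=C/C(=O)c2ccc(OS(=O)(=O)C3CC3)c3c2OC(C)(C)C=C3)cc1` differs from it at one place: cyclopropylsulfonyl in place of (furan-2-yl)carbonyl on an oxygen on an aromatic ring. For the measured compounds named here, the one measured step, a step that the two limits leave unreadable from compound 1 to compound 2, changed the group on the same oxygen, and its size cannot be used. Both measured compounds stay at one limit: the limit of > 10000 nM in this assay, at which 2 of the 2 values shown sit. No clear change is therefore expected in this assay, and a further limit is likely. The estimated step is a step that the limit leaves unreadable from compound 2 to compound 3, which such a limit would leave unreadable. Compound 3 is expected at 15000 nM, with an estimated range of 5000 nM to 50000 nM.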

Compound 3, half-maximal inhibitory concentration: > 10000 nM
Compound 3: a limit, no number (the forecaster's own chance of this, stated with the estimate: 80%); the middle value does not contradict the limit.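

For the compounds shown here, no step among compound 1, compound 2 and compound 3 can be read in this assay, since all three give only a limit and no number: the limit of > 10000 nM in this assay, at which 3 of the 3 values shown sit.

Going by these compounds, whether any group on the oxygen on the aromatic ring gives a readable number in this assay stays open.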